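This account rests on a few compounds, and the source may have more. Where it says the series, first, only, none or still open, it means among the compounds named here.

Measured in a functional assay on MCF7 cells (Homo sapiens) for antiproliferative activity, read by MTT assay, with a stated time of 72 h; a lower number here means a stronger inhibitor, a higher number a weaker inhibitor:

- compound 1 `O=C(N/N=C/c1ccc(F)cc1)Nc1ccc(Oc2ccnc3[nH]ccc23)c(F)c1`: 800 nM
- compound 2 `N#Cc1ccc(/C=N/NC(=O)Nc2ccc(Oc3ccnc4[nH]ccc34)c(F)c2)cc1`: "not active" (no number reported)

Compound 2 stands without a single number, and its result reads "not active" (no number reported). Compound 3 `O=C(N/N=C/c1cccc([N+](=O)[O-])c1)Nc1ccc(Oc2ccnc3[nH]ccc23)c(F)c1` differs from compound 2 in one place: 3-nitrophenyl in place of 4-cyanophenyl on a carbon with a double bond to nitrogen. It carries 3-nitrophenyl in place of 4-cyanophenyl on a carbon with a double bond to nitrogen.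

Among the compounds with values here, no step between measured compounds is available, and the missing number for compound 2 means that none can be calculated for this change. In this assay, the expected step is a modest one in the direction of stronger inhibition, from no reported number to a measurable but weak value. Within the data shown here, the only numerical guide is compound 1 at 800 nM, and compound 3 may well remain without a number. For compound 3, the estimated value is 3000 nM, with an expected range of 600 nM to 15000 nM.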

Compound 3, half-maximal inhibitory concentration: "not active" (no number reported)
Nothing numeric was reported for compound 3; no gap can be computed for the estimate.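

Within the data shown here, compound 3, like compound 2, is reported as "not active" in this assay, so no step between them can be read. The compounds shown leave open what size of change, if any, 3-nitrophenyl in place of 4-cyanophenyl brings, and no measured evidence bears on this result.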